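Replacing isopropyl with bromo on the shared core

The source may hold more compounds than are shown below. What is called first, only, known or untested is meant among the compounds shown, and "the series" means these compounds.

In a physicochemical assay for lipophilicity, at pH 7.4 (a higher number here means a more lipophilic compound, a lower number a more polar compound), compound 1 `CCc1c(C)[nH]c2cc(OC)c(Cl)cc2c1=O` gives 2.43, compound 2 `COc1cc2[nH]c(C)c(C3CCCCC3)c(=O)c2cc1Cl` gives 3.04 and compound 3 `COc1cc2[nH]c(C)c(C(C)C)c(=O)c2cc1Cl` gives 2.84. Compound 3 therefore stands with compound 2 as the upper pair of the three: the gap between them is a number 0.20 log units lower from compound 2 to compound 3 (within the scatter), while the gap to the remaining compound is a number 0.41 log units higher from compound 1 to compound 3 (beyond the scatter).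

The next structure is compound 4 `COc1cc2[nH]c(C)c(Br)c(=O)c2cc1Cl`, with bromo in place of isopropyl on an aromatic carbon. Among the measured compounds shown here, no measured compound carries bromo, so there is no direct precedent. For the measured compounds named here, the only guidance comes from the alkyl groups at this same place, where ethyl in compound 1 gives way to larger groups in a number 0.41 log units higher from compound 1 to compound 3 (beyond the scatter) and a number 0.61 log units higher from compound 1 to compound 2 (beyond the scatter). Both steps are modest, which suggests a change of similar size here, running downward towards compound 1 at 2.43. The expected change is a number 0.44 log units lower from compound 3 to compound 4 (beyond the scatter), a modest fall. For compound 4 the estimate is 2.4, with an expected range from 2 to 2.8.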

Compound 4, distribution coefficient: 0
Compound 4: the middle estimate sits 2.40 log units above what was measured, outside the stated range (below it).
By their numbers in this assay, from the lowest: compound 4; then compound 1; then compounds 3 and 2 (each within the scatter of the next).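

In this assay this position proved far more sensitive than the alkyl groups had indicated: bromo in place of isopropyl gives a number 2.84 log units lower from compound 3 to compound 4 (beyond the scatter) and the same place read against the other two groups gives a number 3.04 log units lower from compound 2 to compound 4 (beyond the scatter) and a number 2.43 log units lower from compound 1 to compound 4 (beyond the scatter). All three steps are large, whereas the changes among ethyl, isopropyl and cyclohexyl on this aromatic carbon stayed modest or within the scatter, so the alkyl groups alone gave no sign of how far the number could move once a different kind of group entered. Nothing measured here accounts for the size of the drop. The compounds shown leave open whether the fall belongs to bromo in particular or would also appear with chloro, a plain hydrogen or a nitrile on the same carbon. They also leave open whether an amine or a methoxy group here would land near compound 4 or near the alkyl compounds.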